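Compound 2: dimethylamino in place of methylsulfanyl

The source may report more compounds than this note shows. Statements on the series, on what has been measured and on what is new or still open speak of the compounds shown alone.

In an ADME assay on HEK293 cells (Homo sapiens) for cytotoxicity, with a stated time of 72 h (a higher number here means that more compound is needed for the effect, a lower number that less compound is needed), compound 1 (`Cc1cc(NC(=O)Nc2ccccc2OC(F)(F)F)c2ccccc2n1`) gives > 25000 nM as a limit of the assay, not a number. Compound 3 (`Cc1cc(NC(=O)Nc2cccc(F)c2)c2ccccc2n1`) gives > 25000 nM as a limit of the same kind. Within the data shown here, compound 2 (`CSc1ccc(NC(=O)Nc2cc(C)nc3ccccc23)cc1`) stands at 24000 nM and carries the only actual number in the set, so it cannot be ranked against the other two. Compound 1 and compound 3 share the limit of > 25000 nM in this assay, at which 2 of the 3 values shown sit, in this small set.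

Compound 4 (`Cc1cc(NC(=O)Nc2ccc(N(C)C)cc2)c2ccccc2n1`) remains to be measured. It has dimethylamino in place of methylsulfanyl on an aromatic carbon of a six-membered aromatic ring of carbon only, para to a large group (dimethylamino in place of methylsulfanyl on an aromatic carbon). Among the measured compounds shown here, no two measured compounds differ in one place, so no measured step speaks to this change. The expectation rests on compound 2 at 24000 nM. It also rests on the limit reached by the other two compounds. No step beyond the scatter is expected in either direction in this assay, and the expected change is a 1.2-fold lower number from compound 2 to compound 4 (0.08 log units; within the scatter) by this estimate. A report of the limit alone would fit this expectation equally well. The estimate for compound 4 is 20000 nM with an expected range of 8000 nM to 25000 nM in the same read-out.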

Compound 4, half-maximal effective concentration: > 25000 nM
Compound 4: no number, only a limit; the forecaster's own chance of this, stated with the estimate: 50%; middle value at least 1.2-fold (0.09 log units) away from the limit.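

Among these compounds, exchanging methylsulfanyl for dimethylamino on an aromatic carbon, para to a large group, gives the first one-place comparison in this assay, and it reads as an at least 1.0-fold higher number from compound 2 to compound 4 (0.01 log units; that floor lies within the scatter) and so gives a floor, not a size. On these data alone, the true distance between the two compounds stays unknown, but this floor gives no sign that the dimethylamino group lowers the number at this position. Among the compounds shown here, the one actual number in the set therefore does not carry over to compound 4, and the series now sits mostly at the top of the measurable range: the limit of > 25000 nM in this assay, at which 3 of the 4 values shown sit.

The compounds shown leave open whether any group at this position can bring the number down beyond the scatter, and a carboxylic acid, a primary amine or a longer chain in place of methylsulfanyl would each test this. They also leave open whether the sulfur of methylsulfanyl matters for the number of compound 2, a question that a methoxy group on the same aromatic carbon would put directly.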